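Ethyl to methyl on compound 2

The compounds below may be only part of what the source reports. "The series", "measured", "known", "first", "only" and "open" are said of these compounds alone.

compound 1 `COc1ccc(SCc2ccc(/C=C/C(=O)Nc3ccccc3N)cc2)cc1OC` gives 65.5% 
compound 2 `CCc1ccc(SCc2ccc(C(=O)Nc3ccccc3N)cc2)cc1` gives 53.6% 
compound 3 `Nc1ccccc1NC(=O)/C=C/c1ccc(CSc2ccc(C(F)(F)F)cn2)cc1` gives 51.7% 

All values come from a functional assay on A549 cells (Homo sapiens) for inhibition, read by CCK-8 assay, with a stated time of 72 h, tested at 2 uM (on this read-out lower numbers stand for less inhibition of growth and higher numbers for more inhibition of growth at the one concentration tested), in this series. Compound 2 at 53.6% lies within the scatter of compound 3 at 51.7%. Compound 1 gives 65.5%, and the gap between compound 1 and compound 2 lies beyond the scatter.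

Compound 4 `Cc1ccc(SCc2ccc(C(=O)Nc3ccccc3N)cc2)cc1` differs from compound 2 by hydrogen in place of methyl on a saturated chain carbon bound to an aromatic carbon in one place (hydrogen in place of methyl on a saturated chain carbon bound to an aromatic carbon), which also reads as ethyl to methyl, or 4-ethylphenyl to 4-methylphenyl.

Within the data shown here, only one measured step offers a size for comparison: a number 13.8 percentage points lower from compound 1 to compound 3 (beyond the scatter) with 5-(trifluoromethyl)pyridin-2-yl in place of 3,4-dimethoxyphenyl on a sulfur. That exchange is far larger than the loss of one methyl, and it gave a modest step. Among the measured compounds shown here, no measured step covers a change this small, so no step beyond the scatter is expected in this assay and no direction can be given. The estimated change is a number 0.4 percentage points higher from compound 2 to compound 4 (within the scatter) (within the scatter). Compound 4 is expected at 54% in this assay with an estimated range from 42% to 66% for repeat measurements.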

Compound 4, percent growth inhibition at one concentration: 40.5%
Compound 4: the middle estimate sits 13.5 percentage points above what was measured, and the stated range ends above it.
By their numbers in this assay, from the lowest: compound 4; then compounds 3 and 2 (each within the scatter of the next); then compound 1.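

In this assay, 4-ethylphenyl to 4-methylphenyl gives a number 13.1 percentage points lower from compound 2 to compound 4 (beyond the scatter), so this place in the series responds to the loss of a single methyl. The earlier compounds gave a size only for a far larger exchange, a number 13.8 percentage points lower from compound 1 to compound 3 (beyond the scatter), and both steps rank as modest, so the size of the change in structure does not set the size of the step among these compounds. Nothing available on these compounds accounts for the step.

Open, as far as these compounds go, is whether a longer chain such as propyl, or an amine in the same place, would follow the ethyl or the methyl compound. Also open, from the compounds shown here alone, is whether ethyl to methyl gives a step of like size on the core of compound 1.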